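Phloroglucinol-type thioesters: one added (methylsulfanyl)carbonyl

This account rests on a few compounds, and the source may have more. Where it says the series, first, only, none or still open, it means among the compounds named here.

Working notes on a small set of polysubstituted phenols run in a functional assay on HCT-116 cells (Homo sapiens) for cytotoxicity, read by sulforhodamine B assay, with a stated time of 72 h; on this read-out higher numbers stand for weaker inhibition and lower numbers for stronger inhibition. Compound 1, `CCc1c(C)c(O)c(C)c(O)c1C(=O)SC`, gives only a limit in this assay, > 40000 nM. Compound 2, `Cc1c(O)cc(C(C)C)c(C)c1O`, likewise gives only a limit in this assay, > 40000 nM. Within the data shown here, both values shown therefore sit at the same point, (the limit of > 40000 nM in this assay, at which 2 of the 2 values shown sit), so no measured step exists in the set and compound 2 stands at the limit with the single other value.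

Compound 3, `CSC(=O)c1c(O)c(C)c(O)c(C)c1C(C)C`, is compound 2 with one change: (methylsulfanyl)carbonyl in place of hydrogen on an aromatic carbon. Among the measured compounds shown here, compound 1 already carries the (methylsulfanyl)carbonyl group on a closely related core and sits at the limit, which is the only guide available. For the measured compounds named here, with no measured step to lean on, the expected outcome is no step beyond the scatter: the step from compound 2 to compound 3 is estimated as a number no higher from compound 2 to compound 3 (the limit leaves the size open). For compound 3 the expected value in this assay is therefore 40000 nM, with a range of 12000 nM to 120000 nM, and most likely the assay again reports only a limit.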

Compound 3, half-maximal inhibitory concentration: 3900 nM
Beside the measured number, compound 3's estimate is 10-fold (1.01 log units) above it; measured number outside the range, below it.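

In this assay the (methylsulfanyl)carbonyl group, placed on the aromatic carbon ortho to a hydroxy group and ortho to an isopropyl group, gives an at least 10-fold lower number from compound 2 to compound 3 (1.01 log units; beyond the scatter) and brings the first measured number into the set. The group is not enough on its own: compound 1 already carries it, and methyl in place of hydrogen on a saturated chain carbon bound to an aromatic carbon and a saturated chain carbon gives an at least 10-fold lower number from compound 1 to compound 3 (1.01 log units; beyond the scatter) as a second step of the same kind. Among these compounds a number clear of the limit therefore appears only where both features are present, and compound 1 and compound 2, each lacking one of them, stay at the limit: the limit of > 40000 nM in this assay, at which 2 of the 3 values shown sit.

From the compounds shown here alone, both steps start from a limit, so their full size remains open, and with a single measured number the set cannot say whether the sulfur atom matters or whether any carbonyl group at this position would serve. A methyl ester or an amide in place of the (methylsulfanyl)carbonyl group, or a tert-butyl group or longer chain in place of the isopropyl group, would separate these possibilities.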